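Replacing naphthalenyl with a methylated trifluoromethyl pyrazole on the thienopyrimidine

The source may hold more compounds than are shown below. What is called first, only, known or untested is meant among the compounds shown, and "the series" means these compounds.

Measured compounds:
compound 1, `C=CS(=O)(=O)N1CCN(c2ncnc3sc(-c4ccc(N5CCN(C)CC5)cc4)cc23)CC1`, 7550 nM
compound 2, `C=CS(=O)(=O)N1CCN(c2ncnc3sc(-c4cccc5ccccc45)cc23)CC1`, 23700 nM

Both compounds share the same core and differ only in the aryl group attached to it. In a functional assay on MDA-MB-231 cells (Homo sapiens) for antiproliferative activity, read by MTT assay, with a stated time of 48 h (on this read-out higher numbers stand for weaker inhibition and lower numbers for stronger inhibition), compound 2 gives 23700 nM, the highest of the two numbers, while compound 1 gives 7550 nM, a gap that lies beyond the usual scatter of this assay.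

Compound 3, `C=CS(=O)(=O)N1CCN(c2ncnc3sc(-c4cn(C)nc4C(F)(F)F)cc23)CC1`, has not yet been measured. It differs from compound 2 in one place: 1-methyl-3-(trifluoromethyl)-1H-pyrazol-4-yl in place of naphthalen-1-yl on an aromatic carbon. The change swaps a carbon-only bicyclic aromatic group for a smaller heteroaromatic ring bearing two acceptors, with no net charge either way.

Within the data shown here, with only two measured compounds and no step yet seen for a change of this kind, the expected step from compound 2 to compound 3 is a 1.7-fold lower number from compound 2 to compound 3 (0.23 log units; within the scatter), a small shift that may not exceed the scatter. Compound 3 is therefore estimated at 14000 nM in this assay, expected to lie between 4500 nM and 45000 nM.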

Compound 3, half-maximal inhibitory concentration: 10400 nM
For compound 3 the middle estimate is 1.3-fold (0.13 log units) above the measured one; the range from low to high includes it.
By their numbers in this assay, from the lowest: compounds 1 and 3 (each within the scatter of the next); then compound 2.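

Among these compounds, at the aromatic carbon next to the ring sulfur, the earlier compounds showed only that two different aryl groups gave different numbers, whereas this change gives a first single-change step, a 2.3-fold lower number from compound 2 to compound 3 (0.36 log units; beyond the scatter), in this assay. The position thus accepts a five-membered aromatic ring with 2 hetero atoms in place of two six-membered aromatic rings of carbon only, at the same count of 10 heavy atoms, and the number does not worsen. No measurement of any property of these groups is available to account for the step.

The compounds shown do not separate the contribution of the pyrazole ring from that of its methyl or trifluoromethyl group. On these data alone, it also remains open how a pyrazole carrying an amine or a carboxylic acid in place of trifluoromethyl would read in this assay at this position.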